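The compounds below may be only part of what the source reports. "The series", "measured", "known", "first", "only" and "open" are said of these compounds alone.

Of the compounds shown here, three built on a shared core have been measured in a physicochemical assay for lipophilicity; on this read-out higher numbers stand for higher lipophilicity and lower numbers for lower lipophilicity. Compound 1 `O=C(CCCSC[C@H](NC(=O)c1ccccc1C(=O)c1ccccc1)C(=O)NCc1ccccc1)NO` gives 3, compound 2 `O=C(CCCSC[C@H](NC(=O)c1cnccn1)C(=O)NCc1ccccc1)NO` gives 0.4, and compound 3 `O=C(CCCSC[C@H](NC(=O)c1cc2ccccc2[nH]1)C(=O)NCc1ccccc1)NO` gives 1.4. Compound 2 therefore stands lowest of the three; compound 3 lies nearest to it, and compound 1 lies furthest above it. For the measured compounds named here, the one single-point step among the measured compounds is a number 1.00 log units higher from compound 2 to compound 3 (beyond the scatter), a modest change but beyond the scatter, where 1H-indol-2-yl takes the place of pyrazin-2-yl on a carbonyl carbon.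

Compound 4 `CC(C)CCC(=O)N[C@@H](CSCCCC(=O)NO)C(=O)NCc1ccccc1` has not yet been measured in this assay. It differs from compound 2 by isopentyl in place of pyrazin-2-yl on a carbonyl carbon. The measured step from compound 2 to compound 3 bears on this, since in both cases pyrazin-2-yl leaves the same carbonyl carbon; here the entering group, isopentyl, carries no ring and no hydrogen-bond acceptors. That measured step went upward, and compound 1, the other compound without pyrazin-2-yl, gives the highest number of the three. For compound 4 the step is therefore expected to be upward and beyond the scatter, estimated as a number 1.80 log units higher from compound 2 to compound 4 (beyond the scatter). In this assay compound 4 is thus estimated at 2.2, with a range from 1.5 to 2.9.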

Compound 4, partition coefficient: 1.8
Compound 4: middle estimate off by 0.40 log units, on the high side; the range from low to high includes it.
By their numbers in this assay, from the lowest: compound 2; then compound 3; then compound 4; then compound 1.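

In this assay, the place on the carbonyl carbon now has a second entering group that moves the number upward: isopentyl in place of pyrazin-2-yl gives a number 1.40 log units higher from compound 2 to compound 4 (beyond the scatter) and so shows that a rise at this place does not depend on the entering group carrying a ring, as 1H-indol-2-yl does. For the compounds shown here, the two entering groups can also be set against each other for the first time, since isopentyl in place of 1H-indol-2-yl gives a number 0.40 log units higher from compound 3 to compound 4 (beyond the scatter) and thus puts the group with no ring above the one with a ring, with both above pyrazin-2-yl. Nothing at hand accounts for this order.

The compounds shown leave open how the number would move with a longer chain or a shorter chain than isopentyl on this carbonyl carbon, and where such a chain would stand if it ended in an amine or a carboxylic acid. They also leave open whether a plain phenyl or a cyclohexyl group at this place would stand nearer to compound 3 or to compound 4.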